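A few compounds are considered here, and "the series" means these few. Any claim that something is new, unique, unknown or untested is made for them only; others in the source may bear on it.

The series starts from compound 1 `COC(=O)c1cc(-c2csc(N/N=C/c3ccc(Cl)cc3Cl)n2)ccc1OCc1ccccc1`, which was tested in a functional assay, read by spectrophotometry; on this read-out higher numbers stand for weaker inhibition and lower numbers for stronger inhibition. In this assay, going by the values given here, compound 1 gives 57.9 ug/mL, the highest of the two numbers measured so far. Among the compounds with values here, the only other measured compound is compound 2 `Cc1ccc(-c2csc(N/N=C/c3cccs3)n2)cc1`; in this assay compound 2 gives 35.9 ug/mL, a number that lies within the usual scatter of the one for compound 1, so the two cannot be told apart on this read-out. Compound 3 `COC(=O)c1cc(-c2csc(N/N=C/c3cccs3)n2)ccc1OCc1ccccc1` has not yet been measured in this assay. Compared with compound 1, it carries thiophen-2-yl in place of 2,4-dichlorophenyl on a carbon with a double bond to nitrogen. Within the data shown here, no measured pair isolates this single change, so there is no step to lean on. Compound 2 also carries a thiophen-2-yl group here, and its number sits close to that of compound 1, so the expected step of a 1.3-fold lower number from compound 1 to compound 3 (0.11 log units; within the scatter) is none beyond the scatter. Compound 3 is therefore estimated at 45 ug/mL, within a range from 20 ug/mL to 110 ug/mL.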

Compound 3, half-maximal inhibitory concentration: 29.2 ug/mL
The estimate for compound 3 lay 1.5-fold (0.19 log units) above the measured number; the measured number falls inside the stated range.
By their numbers in this assay, from the lowest: compounds 3, 2 and 1 (each within the scatter of the next).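

With the rest of the molecule held the same, placing thiophen-2-yl instead of 2,4-dichlorophenyl on the carbon with a double bond to nitrogen gives, in this assay, a 2.0-fold lower number from compound 1 to compound 3 (0.30 log units; within the scatter). Going by these compounds alone, this is the first direct reading of this single change, and it shows that the two compounds cannot be told apart on this read-out, even though the groups differ in ring size, in heavy-atom count and in carrying sulfur or chlorine. Nothing available explains this result or links it to any property of either group.

The compounds shown compare only these two aromatic rings at this position. On these data alone, it remains open whether a group of a different kind there, such as an amine, a carboxylic acid or a longer chain, would produce a step beyond the scatter.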